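Styryl oxadiazole series: dichlorophenyl variant of compound 3

The source may report more compounds than this note shows. Statements on the series, on what has been measured and on what is new or still open speak of the compounds shown alone.

Measured compounds in a functional assay on HeLa cells (Homo sapiens) for cytotoxicity, read by MTT assay, with a stated time of 72 h; on this read-out higher numbers stand for weaker inhibition and lower numbers for stronger inhibition:
compound 1, `CN1CCN(Cc2nnc(-c3cc(S(N)(=O)=O)c(SCc4ccccc4)cc3Cl)o2)CC1`, gives 75000 nM
compound 2, `NS(=O)(=O)c1cc(-c2nnc(CNS(=O)(=O)c3ccc(Cl)cc3)o2)c(Cl)cc1SCc1ccccc1`, gives 24000 nM
compound 3, `NS(=O)(=O)c1cc(-c2nnc(/C=C/c3ccccc3)o2)c(Cl)cc1SCc1ccccc1`, gives 14000 nM

Compound 3 has the lowest number of the three. Its gap to compound 1 is clear, a 5.4-fold lower number from compound 1 to compound 3 (0.73 log units; beyond the scatter), but its gap to compound 2 is not, a 1.7-fold lower number from compound 2 to compound 3 (0.23 log units; within the scatter), so compound 3 and compound 2 cannot be ordered against each other.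

Compound 4, `NS(=O)(=O)c1cc(-c2nnc(/C=C/c3c(Cl)cccc3Cl)o2)c(Cl)cc1SCc1ccccc1`, differs from compound 3 by 2,6-dichlorophenyl in place of phenyl on a double-bonded chain carbon bound to a double-bonded chain carbon. Going by the values given here, none of the measured steps touches the phenyl of the 2-phenylethenyl group: the steps of a 3.1-fold lower number from compound 1 to compound 2 (0.49 log units; beyond the scatter) and a 5.4-fold lower number from compound 1 to compound 3 (0.73 log units; beyond the scatter) swap the whole substituent on the shared core, and a 1.7-fold lower number from compound 2 to compound 3 (0.23 log units; within the scatter) compares two unlike substituents. The effect of chlorine on that ring is therefore unsampled. Among the compounds with values here, with no step to lean on, the expectation for compound 4 is a step of a 1.4-fold lower number from compound 3 to compound 4 (0.15 log units; within the scatter), that is, no change beyond the scatter, leaning slightly to a lower number. Compound 4 is expected at 10000 nM, within 3500 nM to 30000 nM.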

Compound 4, half-maximal inhibitory concentration: 12000 nM
Beside the measured number, compound 4's estimate is 1.2-fold (0.08 log units) below it; the measured number falls inside the stated range.
By their numbers in this assay, from the lowest: compounds 4, 3 and 2 (each within the scatter of the next); then compound 1.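

Going by these compounds alone, on the phenyl of the 2-phenylethenyl group, the only step measured in this assay is the exchange of phenyl for 2,6-dichlorophenyl (a 1.2-fold lower number from compound 3 to compound 4 (0.07 log units; within the scatter)), so the two added chlorine atoms give a number that cannot be told apart from that of the unsubstituted ring. Against the other substituents on the shared core, the dichlorinated styryl group keeps the same picture as the plain one: the step from the methylpiperazine side (a 6.3-fold lower number from compound 1 to compound 4 (0.80 log units; beyond the scatter)) lies beyond the scatter, whereas the step from the sulfonamide side (a 2.0-fold lower number from compound 2 to compound 4 (0.30 log units; within the scatter)) does not. No measurement at hand explains this result.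

From the compounds shown here alone, what a single chlorine on this ring would give remains open. So does the outcome with a carboxylic acid, a methoxy group or an amine on the ring in place of chlorine.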